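Changing the Sulfonyl Group Among Compounds Held at Limits

A few compounds are considered here, and "the series" means these few. Any claim that something is new, unique, unknown or untested is made for them only; others in the source may bear on it.

Measured in an ADME assay on HCT-116 cells (Homo sapiens) for cytotoxicity, read by CellTiter-Glo, with a stated time of 72 h; a higher number here means a weaker inhibitor, a lower number a stronger inhibitor:
- compound 1 `CC1CCN(C2CCN(S(=O)(=O)c3ccc(C#N)cc3)CC2)CC1`: > 5000 nM (a limit)
- compound 2 `CC1CCN(C2CCN(S(=O)(=O)c3cccnc3)CC2)CC1`: > 10000 nM (a limit)
- compound 3 `CC1CCN(C2CCN(S(=O)(=O)c3cccnc3F)CC2)CC1`: > 10000 nM (a limit)

Compound 3 gives > 10000 nM in this assay, and this is a limit, not a number. None of the three compounds has an exact value, so compound 3 cannot be ranked against the others. The record shows (the limit of > 10000 nM in this assay, at which 2 of the 3 values shown sit). It also shows (the limit of > 5000 nM in this assay, at which 1 of the 3 values shown sits).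

The next compound, compound 4 `Cc1nc(Cl)sc1S(=O)(=O)N1CCC(N2CCC(C)CC2)CC1`, keeps the shared core and has 2-chloro-4-methyl-1,3-thiazol-5-yl in place of 2-fluoropyridin-3-yl on a sulfonyl sulfur.

The measured steps that bear on this change all alter the same group or an atom on it: a step that the two limits leave unreadable from compound 1 to compound 2, a step that the two limits leave unreadable from compound 1 to compound 3 and a step that the two limits leave unreadable from compound 2 to compound 3. None of them has a readable size, so none supplies a size to carry over to the new group. Going by these compounds, with compound 3 at > 10000 nM, no step beyond the scatter is expected in this assay, and the direction stays open. The expected change is a number no higher from compound 3 to compound 4 (the limit leaves the size open). A report of only a limit is the likeliest result. For compound 4 the estimate is 10000 nM, with an expected range from 4000 nM to 25000 nM.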

Compound 4, half-maximal inhibitory concentration: > 10000 nM
Compound 4: a limit, no number (the forecaster's own chance of this, stated with the estimate: 85%); the middle value lies on the limit itself.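

Compound 4 gives > 10000 nM in this assay, and this is a limit, not a number. The steps to compound 4 from compound 1, compound 2 and compound 3 each join two limits and cannot be read. The compounds shown leave open whether changing the group on the sulfonyl sulfur alters the exact value in this assay at all, and in which direction.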